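This account rests on a few compounds, and the source may have more. Where it says the series, first, only, none or still open, it means among the compounds named here.

The three measured compounds share the core of compound 1 `COC(=O)c1cc(-c2cccc(NC(=O)c3ccc(/C=C/C(=O)c4cccs4)cc3)c2)on1`. In an ADME assay on Vero cells (Chlorocebus sabaeus) for cytotoxicity, read by MTT assay, with a stated time of 72 h (on this read-out higher numbers stand for lower toxicity in this test and lower numbers for higher toxicity in this test), compound 1 has no reported result, shown as "not determined" (no result reported). Compound 2 `COC(=O)c1cc(-c2cccc(NC(=O)c3ccc(/C=C/C(=O)c4cc(F)ccc4F)cc3)c2)on1` gives in this assay a value that is only a limit of the test, > 40 ug/mL. Compound 3 `COC(=O)c1cc(-c2cccc(NC(=O)c3ccc(/C=C/C(=O)c4cccc(C(F)(F)F)c4)cc3)c2)on1` likewise gives in this assay only a limit, > 20 ug/mL. Among the measured compounds shown here, compound 3 therefore stands at a limit, with one further limit and one entry without a number beside it; the step that the two limits leave unreadable from compound 2 to compound 3 cannot be read, since the limit of > 20 ug/mL in this assay, at which 1 of the 3 values shown sits, and the limit of > 40 ug/mL in this assay, at which 1 of the 3 values shown sits, are the only evidence on the measured values.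

Compound 4 `COC(=O)c1cc(-c2cccc(NC(=O)c3ccc(/C=C/C(=O)c4ccc(Cl)cc4)cc3)c2)on1` differs from compound 3 by 4-chlorophenyl in place of 3-(trifluoromethyl)phenyl on a carbonyl carbon. No readable step bears on this change, and both measured values sit at limits, so no step beyond the scatter is expected, and compound 4 is expected to give 40 ug/mL in this assay, within 20 ug/mL to 80 ug/mL, the expected step being a step that the limit leaves unreadable from compound 3 to compound 4.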

Compound 4, half-maximal cytotoxic concentration: > 50 ug/mL
Compound 4 was reported as a limit (the forecaster's own chance of this, stated with the estimate: 70%); at least 1.2-fold (0.09 log units) between middle value and limit.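

No new step can be read in this assay: the steps from compound 2 and from compound 3 to compound 4 join values that are all limits. The compounds shown leave open whether 2,5-difluorophenyl, 3-(trifluoromethyl)phenyl or 4-chlorophenyl on the carbonyl carbon shifts the half-maximal cytotoxic concentration at all.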